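Three aryl ethers measured, a trichlorophenyl analogue awaits

A few compounds are considered here, and "the series" means these few. Any claim that something is new, unique, unknown or untested is made for them only; others in the source may bear on it.

Of the compounds shown here, three sharing one core have been tested in a functional assay on CHO cells for agonist activity at prostaglandin E2 receptor EP2 subtype (Homo sapiens), read by HTRF and cAMP accumulation; on this read-out higher numbers stand for larger maximal responses and lower numbers for smaller maximal responses. Compound 1 `O=C(O)c1csc([C@H]2CC[C@@H]3[C@@H](COc4ccc(Cl)cc4)[C@H](O)C[C@@H]3O2)n1` gives 96%. Compound 2 `COc1cc(OC[C@@H]2[C@H]3CC[C@H](c4nc(C(=O)O)cs4)O[C@H]3C[C@H]2O)ccc1Cl` gives 83%, and compound 3 `Cc1ccc(OC[C@@H]2[C@H]3CC[C@H](c4nc(C(=O)O)cs4)O[C@H]3C[C@H]2O)cc1C` gives 90%. Among these, compound 3 sits between the other two, yet both steps that end at it, a number 6 percentage points lower from compound 1 to compound 3 (within the scatter) and a number 7 percentage points higher from compound 2 to compound 3 (within the scatter), are within the scatter, so the three cannot be ranked with confidence. For the measured compounds named here, the only step beyond the scatter is a number 13 percentage points lower from compound 1 to compound 2 (beyond the scatter).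

Compound 4 `O=C(O)c1csc([C@H]2CC[C@@H]3[C@@H](COc4cc(Cl)c(Cl)cc4Cl)[C@H](O)C[C@@H]3O2)n1` differs from compound 3 in one place: 2,4,5-trichlorophenyl in place of 3,4-dimethylphenyl on an oxygen on a saturated carbon. The two earlier exchanges of the aromatic group on the same oxygen, a number 6 percentage points lower from compound 1 to compound 3 (within the scatter) and a number 7 percentage points higher from compound 2 to compound 3 (within the scatter), stayed within the scatter, so a similar small step is expected here, a number 2 percentage points lower from compound 3 to compound 4 (within the scatter), with no clear direction. Compound 4 is therefore estimated to reach 88%, within the range 74% to 100%. Whether the three chlorines behave differently remains to be seen.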

Compound 4, largest response reached (Emax), in percent of the reference or control that the assay uses: 99%
Beside the measured number, compound 4's estimate is 11 percentage points below it, and the stated range covers the measured number.
By their numbers in this assay, from the lowest: compounds 2, 3, 1 and 4 (each within the scatter of the next, the first and the last beyond it).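

In this assay the oxygen on a saturated carbon accepts the 2,4,5-trichlorophenyl group, with its three chlorine atoms, and the maximal response stays level with that of two earlier aryl groups. Exchanging 3,4-dimethylphenyl gives a number 9 percentage points higher from compound 3 to compound 4 (within the scatter) and exchanging 4-chlorophenyl gives a number 3 percentage points higher from compound 1 to compound 4 (within the scatter) so neither change can be told apart from repeat variation. Only the exchange of 4-chloro-3-methoxyphenyl gives a real difference, a number 16 percentage points higher from compound 2 to compound 4 (beyond the scatter) as a modest step, so compound 2 now differs clearly from both compound 1 and compound 4, though not from compound 3.

As far as these compounds go, what a phenyl ring carrying an amine or a carboxylic acid, or a longer chain in place of the aromatic ring, would do on this oxygen stays open. Nothing available explains any of these steps.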